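Removing the Amino Link: From Urea Back to Amide

The source may report more compounds than this note shows. Statements on the series, on what has been measured and on what is new or still open speak of the compounds shown alone.

Compound 1 `COc1cc(Cl)cc(-c2nn(-c3cccc(NC(=O)c4ccc(Cl)c(Cl)c4)c3)cc2-c2ccncc2)c1` gives 43.6% in a functional assay on SR cells (Homo sapiens) for inhibition, read by sulforhodamine B assay, with a stated time of 48 h, tested at 10 uM; a higher number here means a weaker effect of the compound at the concentration tested, a lower number a stronger effect.
Compound 2 `COc1cc(Cl)cc(-c2nn(-c3cccc(NC(=O)Nc4ccc(Cl)c(Cl)c4)c3)cc2-c2ccncc2)c1` gives -18.5% in this assay.
Compound 3 `COc1cc(Cl)cc(-c2nn(-c3cccc(NC(=O)Nc4cccc(C(F)(F)F)c4)c3)cc2-c2ccncc2)c1` gives -13.5% in this assay.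

Among the three measured compounds, compound 3 stands second highest. Compound 2 lies close to it, with a number 5 percentage points higher from compound 2 to compound 3 (within the scatter), while compound 1 lies far above it, with a number 57.1 percentage points lower from compound 1 to compound 3 (beyond the scatter).

Compound 4 `COc1cc(Cl)cc(-c2nn(-c3cccc(NC(=O)c4cccc(C(F)(F)F)c4)c3)cc2-c2ccncc2)c1` has not yet been measured. It differs from compound 3 by 3-(trifluoromethyl)phenyl in place of (3-(trifluoromethyl)phenyl)amino on a carbonyl carbon. Two measured steps run in the opposite direction to this change: a number 62.1 percentage points lower from compound 1 to compound 2 (beyond the scatter) and a number 57.1 percentage points lower from compound 1 to compound 3 (beyond the scatter). Each of them puts an amino group onto the carbonyl carbon of a compound built like compound 4, and each lowers the number by a large amount. The step of a number 5 percentage points higher from compound 2 to compound 3 (within the scatter) shows that swapping 3,4-dichlorophenyl for 3-(trifluoromethyl)phenyl on the amide-type nitrogen changes little. Undoing the amino link is therefore expected to raise the number by a large step, a number 53.5 percentage points higher from compound 3 to compound 4 (beyond the scatter). Compound 4 is estimated to give about 40%, in a range from 15% to 65%.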

Compound 4, a percentage reported as activity, at one concentration (the size of the read-out at that concentration, not a potency): 29.1%
For compound 4 the middle estimate is 10.9 percentage points above the measured one, within the range that was stated.
By their numbers in this assay, from the lowest: compounds 2 and 3 (each within the scatter of the next); then compound 4; then compound 1.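

With the same 3-(trifluoromethyl)phenyl group on both sides, removing the amino link gives a number 42.6 percentage points higher from compound 3 to compound 4 (beyond the scatter) and so repeats, on a second aryl group, the large effect seen with 3,4-dichlorophenyl. A step of similar size, a number 47.6 percentage points higher from compound 2 to compound 4 (beyond the scatter) also comes with an aryl change. Among the ureas the aryl swap gave only a number 5 percentage points higher from compound 2 to compound 3 (within the scatter) while among the amides it gives a number 14.5 percentage points lower from compound 1 to compound 4 (beyond the scatter) and so, in these four compounds, the aryl group counts for more once the amino link is gone.

On these data alone, it stays open whether an oxygen on the carbonyl carbon in place of the amino nitrogen, as in a carbamate, would behave like the ureas or the amides. The same holds for a methylene group in that place. Nothing available explains why the amino link has this effect.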